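Two compounds at the limit, one step unread

A few compounds are considered here, and "the series" means these few. Any claim that something is new, unique, unknown or untested is made for them only; others in the source may bear on it.

Measured in an ADME assay on MOLT-3 cells (Homo sapiens) for cytotoxicity, with a stated time of 7 days; a higher number here means that more compound is tolerated, a lower number that less compound is tolerated:
compound 1 `CN(C)c1nc(N)nc2c1ncn2/C=C1/CC1(CO)CO`: "not determined" (no result reported)
compound 2 `CCCSc1nc(N)nc2c1ncn2/C=C1/CC1(CO)CO`: > 20000 nM
compound 3 `Nc1nc(NCc2ccccc2)c2ncn(/C=C3/CC3(CO)CO)c2n1`: > 20000 nM

Compound 3 stands at > 20000 nM, which is a limit of this assay and not a number. Compound 2 gives > 20000 nM, which is also a limit. Together they make up (the limit of > 20000 nM in this assay, at which 2 of the 3 values shown sit), and compound 1 adds no result.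

The next compound is compound 4 `Nc1nc(NC2CC2)c2ncn(/C=C3/CC3(CO)CO)c2n1`. It keeps the shared core of compound 3 and changes one group: cyclopropyl in place of benzyl on a nitrogen on an aromatic ring. In words, cyclopropyl sits in place of benzyl on a nitrogen on an aromatic ring, so benzylamino becomes cyclopropylamino.

Among the measured compounds shown here, one measured step bears on this, because a step that the two limits leave unreadable from compound 2 to compound 3 also exchanges a group on the core. That step has no readable size, so it offers neither a direction nor a magnitude. The plain expectation is therefore that compound 4 stays close to compound 3, with no step beyond the usual scatter, and most likely reports a limit again. The expected change is a number no higher from compound 3 to compound 4 (the limit leaves the size open), and this remains only an estimate. For compound 4 the estimated value is 20000 nM, with an expected range from 7000 nM to 60000 nM.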

Compound 4, half-maximal cytotoxic concentration: > 20000 nM
Compound 4 ended at the assay's limit; the forecaster's own chance of this, stated with the estimate: 70%; the middle value sits exactly at the limit.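

In this assay compound 4 gives > 20000 nM, which is a limit of the assay and not a number. No step among compound 2, compound 3 and compound 4 can be read, since all three sit at that limit: the limit of > 20000 nM in this assay, at which 3 of the 4 values shown sit.

The compounds shown leave open at what concentration any of these three harms the cells, and whether exchanging the group on the shared core shifts that concentration.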